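Isoquinolin-5-yl in place of quinolin-8-yl in compound 1

This account rests on a few compounds, and the source may have more. Where it says the series, first, only, none or still open, it means among the compounds named here.

Among the measured compounds shown here, compound 1 (`CC(=O)OC1=C(c2cccc3cccnc23)Oc2cc3ccccc3cc2-n2cccc21`) gives 360 nM in a physicochemical assay for solubility, in phosphate buffer, with a stated time of 20 min, tested at 15 uM (a lower number here means a less soluble compound, a higher number a more soluble compound), the lower of the two numbers so far. Compound 2 (`CCN(CC)CCCC(C)NC(=O)OC1=C(c2cccc3cccnc23)Oc2cc3ccccc3cc2-n2cccc21`) gives 2890 nM. Compound 3 (`CC(=O)OC1=C(c2cccc3cnccc23)Oc2cc3ccccc3cc2-n2cccc21`) differs from compound 1 in one place: isoquinolin-5-yl in place of quinolin-8-yl on a double-bonded ring carbon. Isoquinolin-5-yl stands in place of quinolin-8-yl on a double-bonded ring carbon. For the measured compounds named here, the only measured step, an 8.0-fold higher number from compound 1 to compound 2 (0.90 log units; beyond the scatter), replaces methyl on a carbonyl carbon and leaves this ring group untouched, so it offers no direct guide to the swap. No change beyond the scatter is therefore expected, and the estimated step is a 1.4-fold higher number from compound 1 to compound 3 (0.14 log units; within the scatter). Compound 3 is estimated at 500 nM, with an expected range of 200 nM to 1500 nM.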

Compound 3, solubility: 220 nM
The estimate for compound 3 lay 2.3-fold (0.36 log units) above the measured number; measured number inside the range.
By their numbers in this assay, from the lowest: compounds 3 and 1 (each within the scatter of the next); then compound 2.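

In this assay, among the compounds shown here, isoquinolin-5-yl in place of quinolin-8-yl on the double-bonded ring carbon gives a 1.6-fold lower number from compound 1 to compound 3 (0.21 log units; within the scatter) and so offers the first reading at this position, where the earlier step had touched only the group on the carbonyl carbon. The same atoms, joined differently in this ring group, leave the two compounds within the scatter of each other. No evidence bears on this result. The compounds shown leave open whether an amine or a carboxylic acid on this ring group would carry the number beyond the scatter.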